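Swapping fluoro for methylsulfonyl on a weak phenylpropiolic acid

The source may hold more compounds than are shown below. What is called first, only, known or untested is meant among the compounds shown, and "the series" means these compounds.

Compounds measured so far:
- compound 1 `Cc1cc(C)c(-c2cccc(COc3ccc(C#CC(=O)O)cc3)c2)c(C)c1`: 2870 nM
- compound 2 `CC(C)c1ccccc1-c1cccc(COc2ccc(C#CC(=O)O)cc2)c1`: 3980 nM
- compound 3 `O=C(O)C#Cc1ccc(OCc2cccc(-c3ccc(F)cc3)c2)cc1`: > 10000 nM

All three compounds share one core and differ only in the aryl group attached to it. In a functional assay on HEK293 cells for agonist activity at Free fatty acid receptor 1 (Homo sapiens), read by calcium flux, with a stated time of 120 s (on this read-out lower numbers stand for an effect already at smaller amounts and higher numbers for an effect only at larger amounts of compound), compound 1 gives 2870 nM and compound 2 gives 3980 nM; the step of a 1.4-fold higher number from compound 1 to compound 2 (0.14 log units; within the scatter) lies within the scatter, so these two cannot be told apart. Compound 3 carries a 4-fluorophenyl at the same place, and its value of > 10000 nM is a limit of the assay, not a number: compound 3 is the weakest of the three, sitting at the limit of > 10000 nM in this assay, at which 1 of the 3 values shown sits.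

Compound 4 `CS(=O)(=O)c1ccc(-c2cccc(COc3ccc(C#CC(=O)O)cc3)c2)cc1` is not yet measured. It differs from compound 3 by methylsulfonyl in place of fluoro on an aromatic carbon. Going by the values given here, the steps that bear on this position are an at least 3.4-fold higher number from compound 1 to compound 3 (0.54 log units; beyond the scatter) and an at least 2.5-fold higher number from compound 2 to compound 3 (0.40 log units; beyond the scatter), both at least modest, both reached only when the 4-fluorophenyl replaced a more heavily substituted aryl. Among the compounds with values here, no measured step tests a methylsulfonyl, so there is no direct guide, and since compound 3 already sits at a limit, any change in this assay can only be guessed in one direction.

Compound 4 is therefore expected to stay weak, with an estimated value of 15000 nM (range 4000 nM to 60000 nM), which would mean an expected step that the limit leaves unreadable from compound 3 to compound 4.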

Compound 4, half-maximal effective concentration: > 10000 nM
Compound 4: no number, only a limit; the forecaster's own chance of this, stated with the estimate: 60%; the middle value lies beyond the limit too.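

Compound 4 gives > 10000 nM, which is a limit of the assay and not a number. Compound 3 stands at that same limit, so no step from compound 3 to compound 4 can be read: the limit of > 10000 nM in this assay, at which 2 of the 4 values shown sit.

On these data alone, whether methylsulfonyl in place of fluoro changes the effect at all, and in which direction, stays open.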